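A few compounds are considered here, and "the series" means these few. Any claim that something is new, unique, unknown or untested is made for them only; others in the source may bear on it.

Measured so far:
compound 1 `O=C(COc1ccc(Cl)cc1)NNC(=S)NCc1ccc(-c2ccccc2)cc1` gives 1200 nM in an assay on isolated protein for inhibition of A disintegrin and metalloproteinase with thrombospondin motifs 5 (Homo sapiens), read by spectrophotometry, with stated times of 10 min and 3 h; on this read-out lower numbers stand for stronger inhibition and higher numbers for weaker inhibition;
compound 2 `O=C(COc1ccc(Cl)c(Cl)c1)NNC(=S)NCc1ccc(-c2ccccc2)cc1` gives 1200 nM in this assay.

Compound 2 stands level with compound 1 on these numbers; the step of no change at the digits printed from compound 1 to compound 2 (within the scatter) lies within the scatter. Compound 3 `O=C(NNC(=S)NCc1ccc(-c2ccccc2)cc1)c1ccc(Cl)cc1` is not yet measured. It differs from compound 2 by 4-chlorophenyl in place of (3,4-dichlorophenoxy)methyl on a carbonyl carbon. Within the data shown here, no measured step bears on this change: the only step in hand, from compound 1 to compound 2, concerns a chloro added on the aromatic ring, not the link to the carbonyl. The expected step of a 1.3-fold higher number from compound 2 to compound 3 (0.10 log units; within the scatter) is therefore set near none beyond the scatter, with a wide range. Compound 3 is estimated at 1500 nM (range 400 nM to 6000 nM).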

Compound 3, half-maximal inhibitory concentration: 700 nM
The estimate for compound 3 lay 2.1-fold (0.33 log units) above the measured number; the range from low to high includes it.
By their numbers in this assay, from the lowest: compounds 3, 1 and 2 (each within the scatter of the next).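

In this assay, 4-chlorophenyl in place of (3,4-dichlorophenoxy)methyl on the carbonyl carbon gives a 1.7-fold lower number from compound 2 to compound 3 (0.23 log units; within the scatter), and in place of (4-chlorophenoxy)methyl it gives a 1.7-fold lower number from compound 1 to compound 3 (0.23 log units; within the scatter). This position therefore holds an aromatic ring set directly on the carbonyl carbon as well as one carried on the longer phenoxymethyl link, with no shift beyond the scatter. The data in hand offer no explanation for this.

Still open, going by these compounds, is how a longer chain or a cyclohexyl group on the carbonyl carbon would read. Also open, on these data alone, is what an amine or a carboxylic acid on the 4-chlorophenyl ring would do.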